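The source may hold more compounds than are shown below. What is called first, only, known or untested is meant among the compounds shown, and "the series" means these compounds.

Measured compounds:
compound 1 `CC(=O)c1cccc(Nc2nc(-c3sc(NC(=O)C(F)(F)F)nc3C)cs2)c1`, in an ADME assay on RD cells (Homo sapiens) for cytotoxicity, read by microscopy (on this read-out higher numbers stand for lower toxicity in this test and lower numbers for higher toxicity in this test), compound 1 gives 30100 nM
compound 2 `CC(=O)c1cccc(Nc2nc(-c3sc(NC(=O)c4ccc(C)cc4)nc3C)cs2)c1`, in this assay compound 2 gives "not determined" (no result reported)

Within the data shown here, compound 1 carries a trifluoroacetyl amide on the shared core and is the only member of the series with a number in this assay. Compound 2 carries the (4-methylphenyl)carbonyl amide instead; it stands nowhere on the numbers, as nothing was determined for it in this assay, so no comparison with compound 1 can be drawn.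

The step from compound 2 leads to compound 3 `CC(=O)c1cccc(Nc2nc(-c3sc(NC(=O)c4ccccc4)nc3C)cs2)c1`. The change is hydrogen in place of methyl on an aromatic carbon; read one bond further out, the 4-methylphenyl becomes phenyl and the benzamido replaces the ((4-methylphenyl)carbonyl)amino group. Among the measured compounds shown here, no measured step of this kind exists, so the size is open. The expectation for this assay is a step of no clear direction and not beyond the scatter.

For compound 3 the expected result in this assay is 25000 nM, estimated within 8000 nM to 80000 nM.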

Compound 3, half-maximal cytotoxic concentration: 11800 nM
The estimate for compound 3 lay 2.1-fold (0.33 log units) above the measured number; measured number inside the range.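

Among these compounds, compound 3 gives the series a second number in this assay, and with it the first reading of the group on the amide carbonyl of the shared core: the record shows a 2.6-fold lower number from compound 1 to compound 3 (0.41 log units; beyond the scatter). Although modest, this step lies beyond the usual scatter, so exchanging trifluoromethyl for phenyl at this carbonyl carbon has a readable effect on the result in this assay, with the lower number standing for higher toxicity in this test. The step between compound 2 and compound 3, methyl to hydrogen on the aromatic carbon para to a large group, cannot be read, as compound 2 has no result, and no measurement shown here accounts for the difference between compound 1 and compound 3.

Among the compounds shown here, with only two numbers at this amide, it remains open where a small acetyl amide or a benzoyl amide carrying a carboxylic acid would fall relative to compound 1 and compound 3. Going by these compounds, the acetyl group and the methyl on the shared core are also constant in all three compounds, so the result of replacing either with an amine remains unknown.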